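Urea pyrazole series: tolerance limits and next analogue

This account rests on a few compounds, and the source may have more. Where it says the series, first, only, none or still open, it means among the compounds named here.

Compound 1, `COc1cc(-c2nn(-c3cccc(NC(=O)Nc4cc(C(F)(F)F)cc(C(F)(F)F)c4)c3)cc2-c2ccncc2)ccc1Cl`, in a functional assay on SNB-19 cells (Homo sapiens) for inhibition, read by sulforhodamine B assay, with a stated time of 48 h (a lower number here means that less compound is tolerated, a higher number that more compound is tolerated), gives > 50000 nM, which is a limit of the assay. Compound 2, `COc1cc(-c2nn(-c3cccc(NC(=O)Nc4ccc(Cl)c(Cl)c4)c3)cc2-c2ccncc2)ccc1Cl`, in this assay gives > 50000 nM, again a limit. Compound 3, `O=C(Nc1cccc(-n2cc(-c3ccncc3)c(-c3ccc(Cl)c(O)c3)n2)c1)Nc1ccc(Cl)c(Cl)c1`, in this assay gives > 32500 nM, also a limit.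

Compound 2 therefore stands only at a limit, and the two further values shown are limits as well: the limit of > 50000 nM in this assay, at which 2 of the 3 values shown sit, and (the limit of > 32500 nM in this assay, at which 1 of the 3 values shown sits). Among the measured compounds shown here, the one step between measured compounds that differ in a single place, a step that the two limits leave unreadable from compound 2 to compound 3, is left unreadable by the two limits, so no measured step carries a readable size.

Compound 4, `COc1cc(-c2nn(-c3cccc(NC(=O)Nc4ccc(Cl)c(C(F)(F)F)c4)c3)cc2-c2ccncc2)ccc1Cl`, differs from compound 2 by trifluoromethyl in place of chloro on an aromatic carbon. For the measured compounds named here, no measured step bears on this change in a readable way; the only related step, the one from compound 2 to compound 3, gives no size. What the series shows is three limits and nothing else.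

The expectation for compound 4 is accordingly a further limit rather than a number: compound 4 is estimated at 60000 nM, with a range from 30000 nM to 150000 nM. The step this estimate means, a step that the limit leaves unreadable from compound 2 to compound 4, is expected to be none beyond the scatter.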

Compound 4, concentration lethal to 50% of the cells: > 32500 nM
Compound 4: only a limit was reported; the forecaster's own chance of this, stated with the estimate: 85%; the middle value lies beyond the limit too.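

Compound 4 gives > 32500 nM in this assay as a limit of the assay. Among the compounds shown here, compound 2 also stands only at a limit, so no step between compound 2 and compound 4 can be read. The compounds shown leave open where any of the four lies as a number in this assay and whether trifluoromethyl in place of chloro changes that number at all.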